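From hydrogen to propanoyl: compound 2 and compound 4

This account rests on a few compounds, and the source may have more. Where it says the series, first, only, none or still open, it means among the compounds named here.

In an ADME assay on N2a cells (Mus musculus) for cytotoxicity, read by MTT assay (a higher number here means a weaker inhibitor, a lower number a stronger inhibitor), compound 2 (`C#CC[C@@H]1C[C@H](n2cccc2)C(=O)O1`) has only a limit, >= 100000 nM. Compound 3 (`C#CC[C@H]1C[C@H](n2cccc2)C(=O)O1`) likewise has only a limit, > 100000 nM. Compound 1 (`C#CC[C@@H]1C[C@H](n2cccc2C(C)=O)C(=O)O1`), which carries acetyl, gives a number, 121000 nM. Compound 4 (`C#CC[C@@H]1C[C@H](n2cccc2C(=O)CC)C(=O)O1`) follows from propanoyl in place of hydrogen on an aromatic carbon. For the measured compounds named here, two measured steps bear on this change, and neither has a readable size: a step that the limit leaves unreadable from compound 1 to compound 2, with hydrogen in place of acetyl, and a step that the two limits leave unreadable from compound 2 to compound 3, a change of configuration only. Resting on compound 1 at 121000 nM, no step beyond the scatter is expected in this assay, and the expected step is a number no higher from compound 2 to compound 4 (the limit leaves the size open). Compound 4 is estimated at 100000 nM, with an expected range from 50000 nM to 200000 nM.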

Compound 4, half-maximal inhibitory concentration: 40600 nM
Beside the measured number, compound 4's estimate is 2.5-fold (0.39 log units) above it; the whole stated range lies above it.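

In this assay, for the compounds shown here, the earlier steps cannot be read, and propanoyl at this place gives the first step with a lower bound, an at least 2.4-fold lower number from compound 2 to compound 4 (0.39 log units; beyond the scatter), though its full size stays open because it rests on a limit: the limit of >= 100000 nM in this assay, at which 1 of the 4 values shown sits. The chain itself also counts here, since methyl in place of hydrogen on the saturated chain carbon gives a 3.0-fold lower number from compound 1 to compound 4 (0.47 log units; beyond the scatter), a readable step beyond the scatter. Compound 4 thus separates from compound 1 at this position. From the compounds shown here alone, whether a butanoyl chain or an amine would lower the number further stays open. The compounds shown also give no cause for either step.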